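From compound 2 to compound 3: one methoxy fewer

A few compounds are considered here, and "the series" means these few. Any claim that something is new, unique, unknown or untested is made for them only; others in the source may bear on it.

Measured in a functional assay on DU-145 cells (Homo sapiens) for cytotoxicity, read by MTT assay, with a stated time of 72 h; on this read-out higher numbers stand for weaker inhibition and lower numbers for stronger inhibition:
Compound 1 `COc1ccc(/C=C/c2cc(C)no2)cc1OC`: > 100000 nM, a limit
Compound 2 `COc1ccc(/C=C/C(=O)CC(C)=O)cc1OC`: 8200 nM

Among the compounds with values here, compound 2 holds the only actual number in this assay, 8200 nM. Compound 1 sits at the limit of > 100000 nM in this assay, at which 1 of the 2 values shown sits. Within the data shown here, the one measured step, an at least 12-fold lower number from compound 1 to compound 2 (1.08 log units; beyond the scatter), is large, but it concerns a different place in the molecule and leaves the methoxy groups untouched. Among the measured compounds shown here, no measured step therefore bears directly on the next change. Compound 3 `COc1ccc(/C=C/C(=O)CC(C)=O)cc1` carries hydrogen in place of methoxy on an aromatic carbon. For the measured compounds named here, with no measured precedent for this change, no firm direction can be assigned, and the expected result is a 1.2-fold higher number from compound 2 to compound 3 (0.09 log units; within the scatter), with no shift clearly beyond the scatter. For compound 3 the estimated value in this assay is 10000 nM, with an expected range of 3500 nM to 30000 nM.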

Compound 3, half-maximal inhibitory concentration: 9100 nM
Beside the measured number, compound 3's estimate is 1.1-fold (0.04 log units) above it; low and high end bracket the measured number.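

In this assay, hydrogen in place of methoxy on the aromatic carbon gives a 1.1-fold higher number from compound 2 to compound 3 (0.05 log units; within the scatter) and thus no shift that this read-out can separate. Of the steps shown, this is the only one on the aromatic ring, and it shows that the methoxy group ortho to the other methoxy group and meta to the group of 8 heavy atoms can give way to hydrogen without a change beyond the scatter, whereas the earlier step, at the other end of the molecule, was large. Nothing among the data shown accounts for this outcome.

On these data alone, whether a hydroxyl group or an amine on this same aromatic carbon would also leave the number in place stays open. So does the part played by the methoxy group that compound 2 and compound 3 share, since hydrogen has replaced only one of the two.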